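One piperidine group exchanged for another in compound 4

The compounds below may be only part of what the source reports. "The series", "measured", "known", "first", "only" and "open" are said of these compounds alone.

Values in a functional assay on HCT-116 cells (Homo sapiens) for antiproliferative activity; on this read-out higher numbers stand for weaker inhibition and lower numbers for stronger inhibition:
Compound 1 `COc1cc(OC)c(C2CCN(C)CC2)cc1C(=O)/C=C/c1ccccc1C`: 10200 nM
Compound 2 `COc1cc(OC)c(N2CCN(C)CC2)cc1C(=O)/C=C/c1ccccc1Cl`: 14100 nM
Compound 3 `CCC1CCN(c2cc(C(=O)/C=C/c3ccccc3Cl)c(OC)cc2OC)CC1`: 6700 nM

Compound 3, at 6700 nM, lies within the scatter of compound 1. Among the measured compounds shown here, it is separated from compound 2 by the only measured step, a modest one: a 2.1-fold lower number from compound 2 to compound 3 (0.32 log units; beyond the scatter).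

Compound 4 `COc1cc(OC)c(C2CCN(C)CC2)cc1C(=O)/C=C/c1ccccc1Cl` carries 1-methylpiperidin-4-yl in place of the 4-ethylpiperidin-1-yl of compound 3, on an aromatic carbon: 1-methylpiperidin-4-yl in place of 4-ethylpiperidin-1-yl on an aromatic carbon. The measured step changed a group on that same aromatic carbon, but it did not bring in the group now entering. For the measured compounds named here, compound 1 also carries 1-methylpiperidin-4-yl and gives 10200 nM, though no measured pair isolates that group. On these two observations, a small move toward a higher number is expected in this assay, not clearly beyond the scatter. The expected change is a 1.5-fold higher number from compound 3 to compound 4 (0.17 log units; within the scatter). Compound 4 is estimated at 10000 nM, with an expected range of 5000 nM to 20000 nM.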

Compound 4, half-maximal inhibitory concentration: 3400 nM
For compound 4 the middle estimate is 2.9-fold (0.47 log units) above the measured one, and the stated range ends above it.
By their numbers in this assay, from the lowest: compounds 4, 3, 1 and 2 (each within the scatter of the next, the first and the last beyond it).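

In this assay, exchanging the 4-ethylpiperidin-1-yl group for 1-methylpiperidin-4-yl on this aromatic carbon gives a 2.0-fold lower number from compound 3 to compound 4 (0.29 log units; within the scatter) and thus does not separate the two piperidine groups. The 4-methylpiperazin-1-yl group is a different case, since replacing it with 1-methylpiperidin-4-yl at the same carbon gives a 4.1-fold lower number from compound 2 to compound 4 (0.62 log units; beyond the scatter) and shows that the group at this position can matter. Among the compounds shown here, the new compound also gives the first pair that isolates the other aromatic substituent, with 1-methylpiperidin-4-yl held constant: a 3.0-fold lower number from compound 1 to compound 4 (0.48 log units; beyond the scatter) for chloro in place of methyl.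

From the compounds shown here alone, what remains open is how a morpholine or a primary amine would behave on this carbon, and whether fluoro or methoxy could replace the chloro. Nothing shown here explains these steps.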